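Hydroxamate series, HDAC6 inhibition: notes toward compound 4

The source may hold more compounds than are shown below. What is called first, only, known or untested is meant among the compounds shown, and "the series" means these compounds.

Measured compounds:
- compound 1 `COc1ccc(C(=O)c2ccc3c(ccn3S(=O)(=O)c3ccc(/C=C/C(=O)NO)cc3)c2)cc1`: 848 nM
- compound 2 `COc1ccc(C(=O)c2ccc3c(ccn3Cc3ccc(C(=O)NO)cc3)c2)cc1OC`: 15.5 nM
- compound 3 `COc1cccc(C(=O)c2ccc3c(ccn3S(=O)(=O)c3cccc(/C=C/C(=O)NO)c3)c2)c1`: 1810 nM

In an assay on isolated protein for inhibition of protein deacetylase HDAC6 (Homo sapiens) (a lower number here means a stronger inhibitor, a higher number a weaker inhibitor), compound 3 gives the highest number of the three. Compound 1 stands closest to it, and that gap lies beyond the scatter; compound 2 stands furthest, far beyond the scatter. No pair of these compounds differs in one place only, so no single step can be read from them, and the numbers of compound 1 and compound 3 can only be set side by side without a cause.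

Compound 4 `O=C(/C=C/c1cccc(S(=O)(=O)n2ccc3cc(C(=O)c4ccc(F)cc4)ccc32)c1)NO` is the next compound. Relative to compound 3 the change is 4-fluorophenyl in place of 3-methoxyphenyl on a carbonyl carbon. Nothing measured here isolates this exchange, so the size of the step in this assay is open; a step within the scatter, in either direction, is the expectation. For compound 4 the estimate is 1500 nM, with a range from 500 nM to 4500 nM. The step from compound 3 to compound 4 is expected to be a 1.2-fold lower number from compound 3 to compound 4 (0.08 log units; within the scatter).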

Compound 4, half-maximal inhibitory concentration: 1420 nM
Beside the measured number, compound 4's estimate is 1.1-fold (0.02 log units) above it; measured number inside the range.
By their numbers in this assay, from the lowest: compound 2; then compounds 1, 4 and 3 (each within the scatter of the next, the first and the last beyond it).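

This pair gives the series its first single-place comparison: in this assay, 4-fluorophenyl in place of 3-methoxyphenyl on a carbonyl carbon gives a 1.3-fold lower number from compound 3 to compound 4 (0.11 log units; within the scatter) and the rest of the molecule stays the same. With the sulfonyl-linked scaffold of compound 3 held constant, this exchange produces no step beyond the scatter, even though the leaving group carries a hydrogen-bond acceptor and the entering group carries none. No supporting measurement bears on this result.

On these data alone, whether this position stays as flat with an amine or a carboxylic acid on the aryl ring, or with the aryl ring replaced by a longer alkyl chain, remains open. The large gap between compound 2 and the other compounds spans more than one place, so no step can be read from it.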